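The compounds below may be only part of what the source reports. "The series", "measured", "known", "first", "only" and "open" are said of these compounds alone.

Compound 1 `COc1cc(OC)c2cc(-c3ccc(OCc4ccccc4)cc3)c(O)nc2c1` carries a benzyl group on an oxygen on its aromatic ring. In a functional assay on A-427 cells (Homo sapiens) for cytotoxicity, read by colorimetric assay and MTT assay (a lower number here means a stronger inhibitor, a higher number a weaker inhibitor), compound 1 gives 10000 nM. Compound 2 `COc1ccc(-c2cc3c(OC)cc(OC)cc3n(CC(=O)OCc3ccccc3)c2=O)cc1` is built on a different core, and the difference between the two cores is not broken down here. In this assay compound 2 gives 10000 nM. Compound 3 `COc1ccc(-c2cc3c(OC)cc(OC)cc3n(CC(=O)O)c2=O)cc1` is made from compound 2 by the change (hydrogen in place of benzyl on an oxygen next to a carbonyl group); in this assay compound 3 gives 10000 nM, and the step of no change at the digits printed from compound 2 to compound 3 (within the scatter). Compound 4 `COc1cc(OC)c2cc(-c3ccc(O)cc3)c(O)nc2c1` arises from compound 1 by the change (hydrogen in place of benzyl on an oxygen on an aromatic ring). This is the same kind of change as that from compound 2 to compound 3, not the same change: in compound 2 the oxygen stands next to a carbonyl group whose other neighbours are carbonyl carbon, while in compound 1 the oxygen stands on an aromatic ring whose other neighbours are aromatic carbon. Because no change at the digits printed from compound 2 to compound 3 (within the scatter) stayed within the scatter, the step of no change at the digits printed from compound 1 to compound 4 (within the scatter) is expected to be equally flat. Compound 4 is therefore estimated at 10000 nM, lying between 3000 nM and 30000 nM.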

Compound 4, half-maximal inhibitory concentration: 10000 nM
Compound 4: middle estimate and measured number agree at the digits printed; low and high end bracket the measured number.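

In this assay, putting hydrogen in place of benzyl on an oxygen on an aromatic ring gives no change at the digits printed from compound 1 to compound 4 (within the scatter). Set beside the earlier step on the other core, this change carries across the two cores with no difference beyond the scatter: the same change on two cores in this assay, no change at the digits printed (within the scatter) from compound 2 to compound 3 and no change at the digits printed (within the scatter) from compound 1 to compound 4, 1.0-fold (0.00 log units) apart, within the scatter of two such steps This shows only that the change leaves the read-out flat on both cores, with compound 1, compound 2, compound 3 and compound 4 all printing one and the same value; it does not show how the change would act on a compound with a lower number, and with no movement on either core the comparison cannot reveal any dependence on the core.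

The compounds shown leave open whether a group other than benzyl or hydrogen on this oxygen, such as an amine-bearing side chain or a longer chain, would shift the number. They also leave open whether replacing the methoxy groups with fluorine or an amine would do so.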